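A Trifluoromethoxy Group in Place of a Hydroxypropyl Chain

This account rests on a few compounds, and the source may have more. Where it says the series, first, only, none or still open, it means among the compounds named here.

Compound 1, `CCn1c(CNc2ccccc2)nnc1SCc1nc2cc(C(=O)C(C)C)ccc2o1`: 600 nM
Compound 2, `CCn1c(CNc2ccccc2)nnc1SCc1nc2cc(C)ccc2o1`: > 1000 nM
Compound 3, `CCC(O)c1ccc2oc(CSc3nnc(CNc4ccccc4)n3CC)nc2c1`: > 1000 nM

All three numbers come from an assay on isolated protein for inhibition of long-chain fatty acid transport protein 1 (Homo sapiens); a higher number here means a weaker inhibitor, a lower number a stronger inhibitor. The value of compound 2 is a limit of this assay, not a number. The value of compound 3 is likewise a limit, and compound 3 therefore stands at the limit of > 1000 nM in this assay, at which 2 of the 3 values shown sit, so no exact number is known for it.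

Compound 4, `CCn1c(CNc2ccccc2)nnc1SCc1nc2cc(OC(F)(F)F)ccc2o1`, differs from compound 3 by trifluoromethoxy in place of 1-hydroxypropyl on an aromatic carbon. Among the measured compounds shown here, no measured step covers this exact exchange. The two steps that alter the same aromatic carbon, an at least 1.6-fold higher number from compound 1 to compound 2 (0.22 log units; that floor lies within the scatter) and an at least 1.6-fold higher number from compound 1 to compound 3 (0.22 log units; that floor lies within the scatter), both end at the limit, and a step that the two limits leave unreadable from compound 2 to compound 3 cannot be read because both of its ends are limits. On that basis compound 4 is expected to sit at or beyond the limit as well, and the expected step that the limit leaves unreadable from compound 3 to compound 4 is one that the data cannot confirm in either direction beyond the scatter. Compound 4 is estimated at 1500 nM, within a range from 500 nM to 5000 nM, with a high chance that this assay again reports only a limit.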

Compound 4, half-maximal inhibitory concentration: 100 nM
Compound 4: middle estimate off by 15-fold (1.18 log units), on the high side; measured number outside the range, below it.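

Trifluoromethoxy on this aromatic carbon gives the first change at this position in this assay that can be read as a gain beyond the scatter, and it improves on the only earlier compound with an exact value: a 6.0-fold lower number from compound 1 to compound 4 (0.78 log units; beyond the scatter). The same group also stands well ahead of the 1-hydroxypropyl and methyl groups, with an at least 10-fold lower number from compound 3 to compound 4 (1.00 log units; beyond the scatter) and an at least 10-fold lower number from compound 2 to compound 4 (1.00 log units; beyond the scatter), so this position is not one where every exchange ends at the limit of the assay. Those last two steps are floors rather than sizes, because the far end of each is a limit: the limit of > 1000 nM in this assay, at which 2 of the 4 values shown sit.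

The compounds shown leave open which part of trifluoromethoxy carries the gain, as the groups compared at this carbon do not separate its oxygen from its fluorines. Going by these compounds, a methoxy group or a trifluoromethyl group on the same aromatic carbon would bear on that question, and whether the gain holds when the rest of the shared core changes also stays open.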